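Swapping the amino for a methyl on the pyrimidine

This account rests on a few compounds, and the source may have more. Where it says the series, first, only, none or still open, it means among the compounds named here.

Measured so far:
compound 1, `Cc1cc(-c2cccc(S(=O)(=O)NC(=O)[C@@H](N)CC(C)C)c2)nc(N)n1`, 160 nM
compound 2, `CC(C)C[C@H](N)C(=O)NS(=O)(=O)c1ccccc1`, 1100 nM
compound 3, `CC(C)C[C@H](N)C(=O)NS(=O)(=O)c1cccc(-c2ccnc(N)n2)c1`, 3900 nM

These three compounds were tested in an assay on isolated protein for inhibition of leucine--tRNA ligase, cytoplasmic (Homo sapiens); on this read-out lower numbers stand for stronger inhibition and higher numbers for weaker inhibition. Compound 3 gives the highest number of the three, which means it is the weakest inhibitor shown: the step of a 3.5-fold higher number from compound 2 to compound 3 (0.55 log units; beyond the scatter) and the step of a 24-fold higher number from compound 1 to compound 3 (1.39 log units; beyond the scatter) both lie beyond the scatter. Compound 1, which carries both the methyl and the amino group on its pyrimidine, is the strongest of the three; the step of a 6.9-fold higher number from compound 1 to compound 2 (0.84 log units; beyond the scatter) shows that dropping the whole pyrimidine from compound 1 costs far less than dropping only its methyl.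

Compound 4, `Cc1cc(-c2cccc(S(=O)(=O)NC(=O)[C@@H](N)CC(C)C)c2)ncn1`, is not yet measured. It differs from compound 3 in one place: 6-methylpyrimidin-4-yl in place of 2-aminopyrimidin-4-yl on an aromatic carbon. The change therefore brings the methyl back but takes the amino group away. The step of a 24-fold higher number from compound 1 to compound 3 (1.39 log units; beyond the scatter) says the methyl is worth a large gain, while nothing measured here tells what the amino group alone contributes. Compound 4 is therefore expected to land well below compound 3, as the step of a 4.9-fold lower number from compound 3 to compound 4 (0.69 log units; beyond the scatter), but with wide uncertainty. The estimate for compound 4 in this assay is 800 nM, within 200 nM to 3000 nM.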

Compound 4, half-maximal inhibitory concentration: 2000 nM
Beside the measured number, compound 4's estimate is 2.5-fold (0.40 log units) below it; the measured number falls inside the stated range.
By their numbers in this assay, from the lowest: compound 1; then compounds 2, 4 and 3 (each within the scatter of the next, the first and the last beyond it).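

Taking only the amino group off the pyrimidine of compound 1 in this assay gives a 13-fold higher number from compound 1 to compound 4 (1.10 log units; beyond the scatter) and taking only the methyl off gives a 24-fold higher number from compound 1 to compound 3 (1.39 log units; beyond the scatter), so each group carries a large step when lost alone. Trading the amino group for the methyl gives a 2.0-fold lower number from compound 3 to compound 4 (0.29 log units; within the scatter) and putting 6-methylpyrimidin-4-yl in place of hydrogen gives a 1.8-fold higher number from compound 2 to compound 4 (0.26 log units; within the scatter), and both steps lie within the scatter, so compound 4 with its methyl alone stands apart from neither neighbour, and the strong inhibition appears only in compound 1, where amino and methyl are present together. No supporting measurement is available to explain why both groups are needed.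

The compounds shown leave open whether another group could stand in for the amino group on the pyrimidine, such as a hydroxyl or a methylamino group. They also leave open whether an ethyl or a trifluoromethyl could take the place of the methyl while the amino group stays.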